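The source may hold more compounds than are shown below. What is called first, only, known or untested is meant among the compounds shown, and "the series" means these compounds.

In a functional assay on HCT-116 cells (Homo sapiens) for inhibition, read by sulforhodamine B assay, with a stated time of 48 h (on this read-out lower numbers stand for stronger inhibition of growth and higher numbers for weaker inhibition of growth), three compounds built on one shared core have been tested so far. Compound 1 `COc1cc(-c2nn(-c3cccc(NC(=O)c4cccc(C(F)(F)F)c4)c3)cc2-c2ccncc2)ccc1Cl` returned only a limit, > 50000 nM. Compound 3 `COc1cc(-c2nn(-c3cccc(NC(=O)c4ccc(Cl)c(C(F)(F)F)c4)c3)cc2-c2ccncc2)ccc1Cl` also returned only a limit, > 32500 nM. Compound 2 `COc1cc(-c2nn(-c3cccc(NC(=O)Nc4cccc(C(F)(F)F)c4)c3)cc2-c2ccncc2)ccc1Cl`, with (3-(trifluoromethyl)phenyl)amino on the carbonyl carbon, gave a real number, 7170 nM. What places compound 3 on the weak side is an at least 4.5-fold higher number from compound 2 to compound 3 (0.65 log units; beyond the scatter).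

Compound 4 `COc1cc(-c2nn(-c3cccc(NC(=O)c4ccccc4)c3)cc2-c2ccncc2)ccc1Cl` comes next, with phenyl in place of 4-chloro-3-(trifluoromethyl)phenyl on a carbonyl carbon. Among the measured compounds shown here, two measured steps bear on this change. Adding the chloro group gave a step that the two limits leave unreadable from compound 1 to compound 3, so that group has no measured size. The only clear gain, an at least 6.9-fold lower number from compound 1 to compound 2 (0.84 log units; beyond the scatter), came from changing what is attached to the carbonyl carbon, and compound 4 does not share that change. A shift beyond the usual scatter is therefore not expected in this assay. The expected step is a step that the limit leaves unreadable from compound 3 to compound 4. The estimate for compound 4 is 40000 nM, within an expected range of 15000 nM to 100000 nM.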

Compound 4, concentration for total growth inhibition: > 100000 nM
Compound 4 was reported as a limit; the forecaster's own chance of this, stated with the estimate: 65%; middle value at least 2.5-fold (0.39 log units) away from the limit.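

Putting phenyl in place of (3-(trifluoromethyl)phenyl)amino on the carbonyl carbon gives, in this assay, an at least 13-fold higher number from compound 2 to compound 4 (1.14 log units; beyond the scatter), which is a large step. Stripping the ring down to plain phenyl also brings back no measurable growth inhibition: compound 4 is reported only as a limit, > 100000 nM. Of the four compounds, only compound 2, with its amino link to the carbonyl carbon, gives a real number, while compound 1, compound 3 and compound 4 all carry limits, and the steps among those three cannot be read.

As far as these compounds go, it remains open whether a plain phenylamino group, without the trifluoromethyl, would keep the activity of compound 2. Also open, from the compounds shown here alone, is whether a nitrile in place of that trifluoromethyl would give a readable value.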